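Azepanyl urea on the shared core: expected loss of potency

The source may report more compounds than this note shows. Statements on the series, on what has been measured and on what is new or still open speak of the compounds shown alone.

Going by the values given here, compound 2 `O=C(C1CCC1)N1CC(c2nc(-c3cccc(Cl)c3)no2)C1` is the only compound here with a numerical result in an assay on HEK293 cells for negative allosteric modulation of metabotropic glutamate receptor 5 (Homo sapiens), read by FLIPR; a lower number here means a stronger inhibitor, a higher number a weaker inhibitor. In this assay compound 2 gives 1500 nM. Compound 1 `O=C(N1CCCCC1)N1CC(c2nc(-c3cccc(Cl)c3)no2)C1` differs from it only at the carbonyl carbon, carrying piperidin-1-yl in place of cyclobutyl. In this assay compound 1 reaches only a limit, > 10000 nM, and no number is known for it. Among the compounds with values here, the one measured step, an at least 6.6-fold lower number from compound 1 to compound 2 (0.82 log units; beyond the scatter), is the sole guide, and it rests on the limit of > 10000 nM in this assay, at which 1 of the 2 values shown sits, rather than on two numbers.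

Compound 3 `O=C(N1CCCCCC1)N1CC(c2nc(-c3cccc(Cl)c3)no2)C1` is the next compound to be measured. It differs from compound 2 by azepan-1-yl in place of cyclobutyl on a carbonyl carbon. This change runs in the opposite sense to the measured step: a nitrogen-linked ring on the carbonyl carbon returns, now one ring size larger than in compound 1. The step from compound 1 to compound 2 was at least modest and beyond the scatter, so the step of a 6.7-fold higher number from compound 2 to compound 3 (0.82 log units; beyond the scatter) is expected to weaken compound 3, perhaps back to the limit. Compound 3 is therefore estimated at 10000 nM, between 3000 nM and 30000 nM, in this assay.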

Compound 3, half-maximal inhibitory concentration: > 10000 nM
Compound 3: no number, only a limit; the forecaster's own chance of this, stated with the estimate: 55%; the middle value lies on the limit itself.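

Going by these compounds alone, compound 3 shows that the weak result of compound 1 is not tied to a single ring size: in this assay, azepan-1-yl on the carbonyl carbon, like piperidin-1-yl, leaves the compound at a limit, and cyclobutyl remains the only group here with a number. The change from cyclobutyl to azepan-1-yl gives an at least 6.6-fold higher number from compound 2 to compound 3 (0.82 log units; beyond the scatter), and the size of this step is only a bound, set by a limit rather than by two numbers. Both nitrogen-linked compounds stand at limits, and the step between them cannot be read, so the two ring sizes remain unordered: the limit of > 10000 nM in this assay, at which 2 of the 3 values shown sit.

The compounds shown leave open whether the weak results go with the ring nitrogen attached to the carbonyl carbon or with the size of the ring, as cyclobutyl differs from piperidin-1-yl and azepan-1-yl in both respects. A cyclohexyl group on the carbonyl carbon would keep the larger ring without that nitrogen, and an azetidin-1-yl group would keep the nitrogen in a four-membered ring, so each would test one of these two differences alone.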